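A few compounds are considered here, and "the series" means these few. Any claim that something is new, unique, unknown or untested is made for them only; others in the source may bear on it.

The measured compounds: compound 1 `N#C/C(=C\c1ccco1)C(=O)NCc1ccc(Cl)c(Cl)c1`, compound 2 `COc1ccc(CNC(=O)/C(C#N)=C/c2ccc(C)o2)cc1` and compound 3 `COc1ccc(CNC(=O)/C(C#N)=C/c2ccc(-c3ccccc3)o2)cc1`.

In a functional assay on A-431 cells (Homo sapiens) for inhibition, read by MTT assay, with a stated time of 72 h (a lower number here means a stronger inhibitor of growth, a higher number a weaker inhibitor of growth), compound 2 gives 58000 nM. For compound 1 the value > 50000 nM is a limit of the assay and not a number. For compound 3 the value > 100000 nM is likewise a limit. Compound 2 therefore stands as the only one of the three with an actual number in this assay; compound 3 sits at the limit of > 100000 nM in this assay, at which 1 of the 3 values shown sits, and compound 1 at the limit of > 50000 nM in this assay, at which 1 of the 3 values shown sits.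

Going by the values given here, the single measured step is an at least 1.7-fold higher number from compound 2 to compound 3 (0.23 log units; that floor lies within the scatter), a swap of the substituent carried on the furan ring. Compound 4 `COc1ccc(CNC(=O)/C(C#N)=C/c2cc(Br)co2)cc1` differs from compound 2 in a different way: 4-bromofuran-2-yl in place of 5-methylfuran-2-yl on a double-bonded chain carbon bound to a double-bonded chain carbon. Among the compounds with values here, no measured step exchanges one furan ring for another, so nothing in the data bears directly on this change. Within the data shown here, with the only comparison available being one whose floor lies within the scatter, no step beyond the scatter is expected in this assay, and an outcome near a limit remains possible.

Compound 4 is estimated at 60000 nM, in the range 20000 nM to 200000 nM, which would mean an expected step of a 1.0-fold higher number from compound 2 to compound 4 (0.01 log units; within the scatter).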

Compound 4, concentration for 50% growth inhibition: 14000 nM
Compound 4: middle estimate off by 4.3-fold (0.63 log units), on the high side; measured number outside the range, below it.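

In this assay, 4-bromofuran-2-yl in place of 5-methylfuran-2-yl gives a 4.1-fold lower number from compound 2 to compound 4 (0.62 log units; beyond the scatter) and is the first step among the compounds shown that lies beyond the scatter. The group on this double-bonded chain carbon can therefore move the number towards stronger inhibition of growth, which the step to compound 3, with its floor within the scatter, could not show. Nothing given here accounts for why this change lowers the number.

This one exchange alters both the substituent and where it sits on the furan, so the compounds shown do not separate the effect of the bromine from that of its place. Going by these compounds, a 5-bromofuran-2-yl or 4-methylfuran-2-yl group at this carbon would part the two, and how either would fare remains open.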